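The compounds below may be only part of what the source reports. "The series", "measured", "known", "first", "only" and "open" are said of these compounds alone.

Measured compounds:
compound 1, `Cc1ccc(-c2nn(-c3ccc(Cl)cc3Cl)cc2C(=O)Nc2ccc(C)c(S(=O)(=O)N3CCOCC3)c2)cc1`, 1240 nM
compound 2, `Cc1ccc(-c2nn(C(C)C)cc2C(=O)Nc2ccc(C)c(S(=O)(=O)N3CCOCC3)c2)cc1`, 1690 nM
compound 3, `Cc1ccc(-c2nn(CC3CC3)cc2C(=O)Nc2ccc(C)c(S(=O)(=O)N3CCOCC3)c2)cc1`, 849 nM

All three values were obtained in an assay on HEK-293T cells for inhibition of Bile acid receptor (Homo sapiens), read by a beta-lactamase reporter, with a stated time of 16 h; a lower number here means a stronger inhibitor, a higher number a weaker inhibitor. Compound 3 gives the lowest number of the three, but its distance to compound 1 and to compound 2 stays within the scatter, so no order among the three is established.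

Compound 4, `Cc1ccc(-c2nn(-c3ccccc3)cc2C(=O)Nc2ccc(C)c(S(=O)(=O)N3CCOCC3)c2)cc1`, has not been measured. The change from compound 3 is phenyl in place of cyclopropylmethyl on an aromatic nitrogen. Going by the values given here, the steps that bear on it are those at the same aromatic nitrogen: a 1.5-fold lower number from compound 1 to compound 3 (0.16 log units; within the scatter) and a 2.0-fold lower number from compound 2 to compound 3 (0.30 log units; within the scatter), with a 1.4-fold higher number from compound 1 to compound 2 (0.13 log units; within the scatter) connecting the two starting points. Among the compounds with values here, every exchange at this position so far, whether an aryl or an alkyl group was put there, has stayed within the scatter. Compound 1 carries an aryl group at this nitrogen, as compound 4 does, and gives a number close to compound 3.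

On that basis compound 4 is expected to give 1100 nM in this assay, with a range from 500 nM to 2500 nM. The expected step of a 1.3-fold higher number from compound 3 to compound 4 (0.11 log units; within the scatter) is estimated to remain within the scatter, with no clear direction.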

Compound 4, half-maximal inhibitory concentration: 2620 nM
Estimate against measurement, compound 4: 2.4-fold (0.38 log units) below, and the stated range ends below it.
By their numbers in this assay, from the lowest: compounds 3, 1, 2 and 4 (each within the scatter of the next, the first and the last beyond it).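

In this assay, this aromatic nitrogen now shows exchanges beyond the scatter, though only modest ones: a 3.1-fold higher number from compound 3 to compound 4 (0.49 log units; beyond the scatter) for phenyl in place of cyclopropylmethyl. Carrying an aryl group does not by itself set the level, as phenyl also separates from 2,4-dichlorophenyl, with a 2.1-fold higher number from compound 1 to compound 4 (0.32 log units; beyond the scatter), so the two chlorines count as part of the difference at this position. The alkyl groups do not fall together either: a 1.6-fold higher number from compound 2 to compound 4 (0.19 log units; within the scatter) stays within the scatter, so phenyl is separated from cyclopropylmethyl but not from isopropyl.

Nothing on hand gives a reason for these steps. Still open, going by these compounds, is how a single chlorine on the phenyl, or an amine or a carboxylic acid at the end of a longer chain on this nitrogen, would read.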